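Cyclopentyl Amide to Ethyl Carbamate in Compound 3

The compounds below may be only part of what the source reports. "The series", "measured", "known", "first", "only" and "open" are said of these compounds alone.

Going by the values given here, compound 3 `Cc1cc(NC(=O)C2CCCC2)nn1Cc1cc(Cl)ccc1OCc1ccccc1` gives 3.5 in a physicochemical assay for lipophilicity, at pH 7.4 (a higher number here means a more lipophilic compound, a lower number a more polar compound), the only plain number among the three values shown. Compound 1 `Cc1cc(C(=O)NC(C)C)nn1Cc1cc(Cl)ccc1OCc1ccccc1` gives in this assay only a limit, > 3.7. Compound 2 `Cc1cc(C(=O)NCc2ccccc2)nn1Cc1cc(Cl)ccc1OCc1ccccc1` likewise gives only a limit, > 3.7, as recorded in the limit of > 3.7 in this assay, at which 2 of the 3 values shown sit. Among the compounds with values here, the step of a number at least 0.20 log units lower from compound 1 to compound 3 (that floor lies within the scatter) and the step of a number at least 0.20 log units lower from compound 2 to compound 3 (that floor lies within the scatter) are the only measured steps touching the amide region, and neither alters the group on the carbonyl carbon. Compound 4 `CCOC(=O)Nc1cc(C)n(Cc2cc(Cl)ccc2OCc2ccccc2)n1` differs from compound 3 by ethoxy in place of cyclopentyl on a carbonyl carbon. Within the data shown here, no measured step matches this change, so the expectation rests on the counted difference alone: a step of a number 0.90 log units lower from compound 3 to compound 4 (beyond the scatter) is expected. Compound 4 is therefore estimated at 2.6, within 2.1 to 3.1.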

Compound 4, distribution coefficient: > 3.7
Compound 4 was reported as a limit; the forecaster's own chance of this, stated with the estimate: 5%; middle value at least 1.10 log units away from the limit.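

Ethoxy in place of cyclopentyl on a carbonyl carbon gives a number at least 0.20 log units higher from compound 3 to compound 4 (that floor lies within the scatter) in this assay, the first reading of any change to the group at this position. Compound 4 gives > 3.7 as a limit of the assay, not a number. The steps linking compound 1 and compound 2 to compound 4 cannot be read, as all three sit at one limit: the limit of > 3.7 in this assay, at which 3 of the 4 values shown sit.

On these data alone, how far compound 4 lies past that limit stays open, and with it the true size of the step. Also open, as far as these compounds go, is how a longer alkoxy chain or an amine on the same carbonyl carbon would read in this assay.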